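Aryl urea series: methoxy in place of trifluoromethyl

The compounds below may be only part of what the source reports. "The series", "measured", "known", "first", "only" and "open" are said of these compounds alone.

Of the compounds shown here, two have been measured in an ADME assay on the whole organism with Oryza sativa as the target, tested at 1 uM; on this read-out lower numbers stand for a stronger effect and higher numbers for a weaker effect at the one concentration tested. Compound 1 `CC(C)c1cccc(NC(=O)N[C@H](C)c2ccccc2)c1` gives 61% in this assay. Among the compounds with values here, compound 2 `C[C@@H](NC(=O)Nc1cccc(C(F)(F)F)c1)c1ccccc1` gives 72% in this assay, the higher of the two numbers, and the single measured step, a number 11 percentage points higher from compound 1 to compound 2 (beyond the scatter), separates them. Compound 2 thus stands at the weaker end of what has been seen so far.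

Compound 3 `COc1cccc(NC(=O)N[C@H](C)c2ccccc2)c1` is not yet measured. It differs from compound 2 in one place: methoxy in place of trifluoromethyl on an aromatic carbon. Within the data shown here, no measured step exchanges trifluoromethyl for methoxy, so the step from compound 1 to compound 2 bears only indirectly, as a sign that a change at this position can shift the read-out by a modest amount beyond the scatter. The direction for compound 3 is open, and the expected step is a number 6 percentage points lower from compound 2 to compound 3 (within the scatter). The estimate for compound 3 in this assay is 66%, with a range from 52% to 80%.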

Compound 3, a percentage reported as activity, at one concentration (the size of the read-out at that concentration, not a potency): 92%
The estimate for compound 3 lay 26 percentage points below the measured number; measured number outside the range, above it.
By their numbers in this assay, from the lowest: compound 1; then compound 2; then compound 3.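

In this assay, the change at this aromatic carbon gives a number 20 percentage points higher from compound 2 to compound 3 (beyond the scatter), and the comparison with the isopropyl group gives a number 31 percentage points higher from compound 1 to compound 3 (beyond the scatter). Compound 3 therefore has the weakest effect of the three at the one concentration tested, and this position can move the read-out much further than the isopropyl to trifluoromethyl step alone had suggested. The exchange of trifluoromethyl for methoxy introduces 1 hydrogen-bond acceptor and leaves fewer heavy atoms, but a single pair cannot separate these differences, and no available measurement explains the higher number.

The compounds shown leave open whether the result belongs to the methoxy group as a whole or specifically to its oxygen, a question that a hydroxyl group, an ethoxy chain or an amine at this carbon could help resolve. On these data alone, it also remains open whether the order of isopropyl, trifluoromethyl and methoxy seen here would hold with these groups on another carbon of the aromatic ring.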